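Removing the chloro group from compound 3

The source may hold more compounds than are shown below. What is called first, only, known or untested is meant among the compounds shown, and "the series" means these compounds.

Compound 1 `Cc1ccc(C2CNC(=O)N2S(=O)(=O)c2ccc3c(c2)CCC3)cc1`: 90300 nM
Compound 2 `O=C1NCC(c2ccc(Br)cc2)N1S(=O)(=O)c1ccc2c(c1)CCC2`: > 237000 nM, a limit
Compound 3 `O=C1NCC(c2ccc(Cl)cc2)N1S(=O)(=O)c1ccc2c(c1)CCC2`: > 265000 nM, a limit
Compound 4 `O=C1NCC(c2ccccc2)N1S(=O)(=O)c1ccc2c(c1)CCC2`: not yet measured

In a functional assay on A549 cells (Homo sapiens) for cytotoxicity (a lower number here means a stronger inhibitor, a higher number a weaker inhibitor), compound 3 is known only through a limit, > 265000 nM. Compound 4 carries hydrogen in place of chloro on an aromatic carbon, para to a large group (hydrogen in place of chloro on an aromatic carbon). Two measured steps at this place bear on the change: chloro in place of methyl gave an at least 2.9-fold higher number from compound 1 to compound 3 (0.46 log units; beyond the scatter), and bromo in place of methyl gave an at least 2.6-fold higher number from compound 1 to compound 2 (0.41 log units; beyond the scatter). Chloro in place of bromo gave a step that the two limits leave unreadable from compound 2 to compound 3. Among the measured compounds shown here, no step to hydrogen has been measured, so only a modest move to a lower number is expected, with compound 1 at 90300 nM as the sole numeric anchor. The expected change is an at least 1.5-fold lower number from compound 3 to compound 4 (0.19 log units; that floor lies within the scatter). For compound 4 the estimated value is 170000 nM, with an expected range of 80000 nM to 350000 nM.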

Compound 4, half-maximal inhibitory concentration: 58500 nM
The estimate for compound 4 lay 2.9-fold (0.46 log units) above the measured number, outside the stated range (below it).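

In this assay, hydrogen in place of chloro gave an at least 4.5-fold lower number from compound 3 to compound 4 (0.65 log units; beyond the scatter), and hydrogen in place of bromo gave an at least 4.0-fold lower number from compound 2 to compound 4 (0.60 log units; beyond the scatter); both steps start from limits of the assay, so each size is a floor. Hydrogen in place of methyl gave a 1.5-fold lower number from compound 1 to compound 4 (0.19 log units; within the scatter), so the methyl and unsubstituted compounds do not separate, and only the chloro and bromo compounds stand apart from them. The halogens thus account for the shift at this place, not the methyl group.

The step between compound 2 and compound 3 cannot be read, as both are limits. As far as these compounds go, how an amine or a carboxylic acid would read at this place remains open.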